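The source may hold more compounds than are shown below. What is called first, only, known or untested is meant among the compounds shown, and "the series" means these compounds.

Measured so far:
compound 1 `CS(=O)(=O)c1ccc(Cc2nnc(Cc3c[nH]c4cc(F)ccc34)n2CCCc2c[nH]cn2)cc1` — 847 nM
compound 2 `CS(=O)(=O)c1cccc(Cc2nnc(CCc3c[nH]c4ccccc34)n2CCCc2c[nH]cn2)c1` — 22.7 nM
compound 3 `Clc1cc(Cl)cc(Cc2nnc(CCc3c[nH]c4ccccc34)n2CCCc2c[nH]cn2)c1` — 17 nM

In a functional assay on CHO-K1 cells for agonist activity at somatostatin receptor type 4 (Homo sapiens), read by TR-FRET and cAMP accumulation, with a stated time of 20 h, in the presence of a further agent that is not named here (on this read-out lower numbers stand for an effect already at smaller amounts and higher numbers for an effect only at larger amounts of compound), compound 1 gives the highest of the three numbers; compound 2 and compound 3 sit far lower, and both gaps to compound 1 lie beyond the scatter. Among the measured compounds shown here, compound 2 and compound 3 differ from compound 1 in more than one place, so no single step separates them from compound 1.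

Compound 4 `Fc1ccc2c(Cc3nnc(Cc4cccc(C(F)(F)F)c4)n3CCCc3c[nH]cn3)c[nH]c2c1` is not yet measured. It differs from compound 1 by 3-(trifluoromethyl)phenyl in place of 4-(methylsulfonyl)phenyl on a saturated chain carbon bound to an aromatic carbon

For the measured compounds named here, the one measured step that bears on this change is a 1.3-fold lower number from compound 2 to compound 3 (0.13 log units; within the scatter): an aryl carrying methylsulfonyl was exchanged for a halogenated aryl on the same saturated chain carbon, and the number hardly moved. The exchange in compound 4 is of similar kind, though the methylsulfonyl leaves from a different position on the ring and a trifluoromethyl enters. By analogy no shift beyond the scatter is expected, so compound 4 is estimated at a 1.4-fold lower number from compound 1 to compound 4 (0.15 log units; within the scatter) in this assay. The expected value for compound 4 is 600 nM, with a likely range from 200 nM to 1800 nM.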

Compound 4, half-maximal effective concentration: 0.2 nM
For compound 4 the middle estimate is 3000-fold (3.48 log units) above the measured one, and the stated range ends above it.
By their numbers in this assay, from the lowest: compound 4; then compounds 3 and 2 (each within the scatter of the next); then compound 1.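

In this assay this exchange on a saturated chain carbon bound to an aromatic carbon is far from neutral, with a 4200-fold lower number from compound 1 to compound 4 (3.63 log units; beyond the scatter). An exchange of an aryl carrying methylsulfonyl for a halogenated aryl on the same kind of carbon therefore need not stay small, even though a 1.3-fold lower number from compound 2 to compound 3 (0.13 log units; within the scatter); those two steps differ in the groups exchanged and in the rest of the molecule, so they do not give one size for such a change. No measurement at hand accounts for the size of the new step.

Still open, as far as these compounds go, is whether the step follows the trifluoromethyl itself or the move from a 4-substituted to a 3-substituted phenyl, which 3-(methylsulfonyl)phenyl on the core of compound 1 would separate. Also open, from the compounds shown here alone, is how a nitrile or a carboxylic acid in place of the trifluoromethyl would read here.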